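The source may hold more compounds than are shown below. What is called first, only, known or untested is meant among the compounds shown, and "the series" means these compounds.

In a functional assay on A2780 cells (Homo sapiens) for antiproliferative activity, read by MTT assay, with a stated time of 48 h (a higher number here means a weaker inhibitor, a lower number a stronger inhibitor), three compounds have been measured so far, all sharing a methoxy-bearing aromatic ring that carries an amide of a small amino acid. Compound 1, `COc1ccc(C(=O)c2ccc(OC)c3c2C=CC(C)(C)O3)c(NC(=O)CN)c1`, gives 890 nM in this assay. Compound 2, `CNCC(=O)Nc1cc(OC)ccc1C(=O)c1ccc(OC)c2c1C=CC(C)(C)O2`, differs from it by methyl in place of hydrogen on an amine nitrogen and gives 1590 nM, so the step of a 1.8-fold higher number from compound 1 to compound 2 (0.25 log units; within the scatter) is a small one. Compound 3, `C=C(c1cc(OC)c(OC)c(OC)c1)c1ccc(OC)cc1NC(=O)CN`, rests on a different core, and how its core differs from that of compound 1 is not broken down here. In this assay compound 3 gives 30 nM, which is the lowest of the three numbers and stands well apart from the other two.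

Compound 4, `C=C(c1cc(OC)c(OC)c(OC)c1)c1ccc(OC)cc1NC(=O)CNC`, has not yet been measured. Among the compounds with values here, it is built from compound 3 by methyl in place of hydrogen on an amine nitrogen, which is the same change, at the same kind of place, as the one that turned compound 1 into compound 2. Because that earlier step a 1.8-fold higher number from compound 1 to compound 2 (0.25 log units; within the scatter) stayed within the usual scatter, the expectation is that the step of a 1.7-fold higher number from compound 3 to compound 4 (0.22 log units; within the scatter) will be modest as well, and that compound 4 keeps most of the strength of compound 3 rather than falling back toward compound 1 or compound 2. Compound 4 is therefore estimated to give about 50 nM in this assay, with a plausible range from 22 nM to 130 nM.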

Compound 4, half-maximal inhibitory concentration: 140 nM
Beside the measured number, compound 4's estimate is 2.8-fold (0.45 log units) below it, outside the stated range (above it).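

On the core of compound 3, methyl in place of hydrogen on the amine nitrogen gives, in this assay, a 4.7-fold higher number from compound 3 to compound 4 (0.67 log units; beyond the scatter), so here the change clearly weakens the compound. Set beside the same change on the core of compound 1, the step goes in the same direction, and the gap in size does not separate the two cores: the same change on two cores in this assay, a 1.8-fold higher number (0.25 log units; within the scatter) from compound 1 to compound 2 and a 4.7-fold higher number (0.67 log units; beyond the scatter) from compound 3 to compound 4, 2.6-fold (0.42 log units) apart, within the scatter of two such steps This suggests that the change carries over from one core to the other in this series, at least in direction, but it does not show that the core of compound 3 is truly more sensitive to the methyl, and two pairs of compounds cannot show how the change would behave on any further core.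

The compounds shown compare only hydrogen and methyl on this nitrogen, so it remains open whether an ethyl group or a second methyl there would push the number further in the same direction. Also open, on these data alone, is how either core would respond to a longer chain carrying the amine, or to a hydroxyl group or a carboxylic acid in place of the amine.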